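Swapping a benzyl substituent: expected cytotoxicity of compound 4

The source may report more compounds than this note shows. Statements on the series, on what has been measured and on what is new or still open speak of the compounds shown alone.

Three compounds sharing one core were measured in an ADME assay on MT2 cells (Homo sapiens) for cytotoxicity, read by XTT assay, with a stated time of 4 days; a higher number here means that more compound is tolerated, a lower number that less compound is tolerated. Compound 1 `Cc1cc(/C=C2\SC(=S)N(Cc3ccccc3)C2=O)c(C)n1-c1ccc(O)c(C(=O)O)c1` gives 159000 nM. Compound 2 `Cc1cc(/C=C2\SC(=S)N(Cc3cccc(C(F)(F)F)c3)C2=O)c(C)n1-c1ccc(O)c(C(=O)O)c1` gives 26300 nM in this assay. Compound 3 `COC(=O)c1cccc(CN2C(=O)/C(=C/c3cc(C)n(-c4ccc(O)c(C(=O)O)c4)c3C)SC2=S)c1` gives 38500 nM in this assay, the second highest of the three numbers; its nearest neighbour is compound 2, within the scatter, and compound 1 sits furthest away. Compound 4 `Cc1cc(/C=C2\SC(=S)N(Cc3ccccc3Br)C2=O)c(C)n1-c1ccc(O)c(C(=O)O)c1` has not yet been measured. It differs from compound 3 in one place: 2-bromophenyl in place of 3-(methoxycarbonyl)phenyl on a saturated chain carbon bound to an amide-type nitrogen in a ring. Going by the values given here, two measured steps bear on this change. Putting a substituent onto the benzyl group gave a 6.0-fold lower number from compound 1 to compound 2 (0.78 log units; beyond the scatter) and a 4.1-fold lower number from compound 1 to compound 3 (0.62 log units; beyond the scatter), while exchanging one substituent for another gave a 1.5-fold higher number from compound 2 to compound 3 (0.17 log units; within the scatter). Both substituted benzyls thus lie close together and well below compound 1. The 2-bromobenzyl group is a third substituted benzyl, so compound 4 is expected to behave like compound 2 and compound 3, with a step of a 1.3-fold lower number from compound 3 to compound 4 (0.11 log units; within the scatter) that stays within the scatter. The estimate for compound 4 in this assay is 30000 nM, with a range from 12000 nM to 75000 nM.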

Compound 4, half-maximal cytotoxic concentration: 25700 nM
Compound 4: middle estimate off by 1.2-fold (0.07 log units), on the high side, within the range that was stated.
By their numbers in this assay, from the lowest: compounds 4, 2 and 3 (each within the scatter of the next); then compound 1.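

Replacing hydrogen with bromo in this assay gives a 6.2-fold lower number from compound 1 to compound 4 (0.79 log units; beyond the scatter), so the lower number seen with 3-(trifluoromethyl)phenyl and 3-(methoxycarbonyl)phenyl is not confined to those two groups. The new compound cannot be told apart from the other two substituted compounds, with a 1.5-fold lower number from compound 3 to compound 4 (0.18 log units; within the scatter) and a 1.0-fold lower number from compound 2 to compound 4 (0.01 log units; within the scatter), although 2-bromophenyl carries no hydrogen-bond acceptors and 3-(methoxycarbonyl)phenyl does. No supporting measurement is available to explain this result.

The compounds shown leave open whether an amine or a carboxylic acid on the benzyl ring would stay close to compound 2, compound 3 and compound 4 or come nearer to compound 1. Going by these compounds, whether a longer chain in place of the benzyl group would hold this level also remains open.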